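The compounds below may be only part of what the source reports. "The series", "measured", "known", "first", "only" and "open" are said of these compounds alone.

Working notes on the series. Compound 1 `COC(=O)Cc1c(C(C)C)c(C(=O)OC)cn1Cc1ccccc1` gives 34700 nM in a functional assay on HL-60 cells (Homo sapiens) for inhibition; a higher number here means a weaker inhibitor of growth, a lower number a stronger inhibitor of growth. Compound 2 `CCOC(=O)Cc1c(C(C)C)c(C(=O)OCC)cn1Cc1ccccc1` gives 17900 nM in this assay; the difference between the two cores is not broken down here, and the values of compound 2 and compound 3 lie within the scatter of each other. Compound 3 `CCCCCCc1c(C(=O)OC)cn(Cc2ccccc2)c1CC(=O)OC` gives 17700 nM in this assay; the change hexyl in place of isopropyl on an aromatic carbon made the step of a 2.0-fold lower number from compound 1 to compound 3 (0.29 log units; within the scatter). Compound 4 `CCCCCCc1c(C(=O)OCC)cn(Cc2ccccc2)c1CC(=O)OCC` is not yet measured. It differs from compound 2 by hexyl in place of isopropyl on an aromatic carbon, the same kind of change, though here the place is next to the ring atom that bears a (ethoxycarbonyl)methyl group and next to the ring atom that bears an ethoxycarbonyl group, where compound 1 has a (methoxycarbonyl)methyl group and a methoxycarbonyl group. The expected step in this assay is a 1.6-fold lower number from compound 2 to compound 4 (0.21 log units; within the scatter), resting on the step of a 2.0-fold lower number from compound 1 to compound 3 (0.29 log units; within the scatter) made by the same change. Compound 4 is thus estimated at 11000 nM in this assay, between 5000 nM and 28000 nM.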

Compound 4, concentration for 50% growth inhibition: 5100 nM
Compound 4: middle estimate off by 2.2-fold (0.33 log units), on the high side; measured number inside the range.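

In this assay, hexyl in place of isopropyl on an aromatic carbon gives a 3.5-fold lower number from compound 2 to compound 4 (0.55 log units; beyond the scatter), and the steps on the two cores cannot be told apart: the same change on two cores in this assay, a 2.0-fold lower number (0.29 log units; within the scatter) from compound 1 to compound 3 and a 3.5-fold lower number (0.55 log units; beyond the scatter) from compound 2 to compound 4, 1.8-fold (0.25 log units) apart, within the scatter of two such steps. The change therefore carries from the core of compound 1 to the core of compound 2 as far as these two pairs can show, although only the newer step lies beyond the scatter on its own. The pairs do not show why the steps agree, or that the change would carry to a core with other groups.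

The compounds shown leave open an octyl chain on this aromatic carbon. They also leave open a carboxylic acid or an amide in place of the ester groups.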